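The source may report more compounds than this note shows. Statements on the series, on what has been measured and on what is new or still open speak of the compounds shown alone.

Measured so far:
Compound 1 `O=C(O)COc1cc(Cl)c(C(=O)Nc2cccc(-c3nc4ccccc4s3)c2)cc1[N+](=O)[O-]`: > 25000 nM
Compound 2 `Cc1ccc(-c2nc3ccccc3s2)cc1NC(=O)c1cc([N+](=O)[O-])c(N(C)C)cc1Cl`: > 25000 nM

Both entries come from an ADME assay on HEK293 cells (Homo sapiens) for cytotoxicity, with a stated time of 72 h (on this read-out higher numbers stand for an effect only at larger amounts of compound and lower numbers for an effect already at smaller amounts), and neither is a true number. Compound 2 gives > 25000 nM, which is a limit of the assay. Compound 1 gives > 25000 nM, which is also a limit. The position of compound 2 is therefore simple to state: it stands at the limit of > 25000 nM in this assay, at which 2 of the 2 values shown sit.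

The next compound to be tested is compound 3 `Cc1ccc(-c2nc3ccccc3s2)cc1NC(=O)c1cc([N+](=O)[O-])ccc1Cl`. It has hydrogen in place of dimethylamino on an aromatic carbon, ortho to a nitro group and meta to a chloro group, while the rest of compound 2 stays the same: hydrogen in place of dimethylamino on an aromatic carbon.

Among the compounds with values here, no pair of measured compounds differing in one place is available to size this change in this assay. The expectation rests only on compound 2 sitting at the limit > 25000 nM. No step beyond the usual scatter is expected, and another limit is the likeliest report. The estimated change is a number no higher from compound 2 to compound 3 (the limit leaves the size open). The expected value for compound 3 is 25000 nM, with an estimated range from 12000 nM to 50000 nM.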

Compound 3, half-maximal effective concentration: > 14000 nM
Compound 3: no number, only a limit; the forecaster's own chance of this, stated with the estimate: 75%; the middle value does not contradict the limit.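

In this assay compound 3 gives > 14000 nM, which is a limit and not a number. Compound 2 is also reported only as a limit, and no step can be read between compound 2 and compound 3. The compounds shown leave open what true half-maximal effective concentration any of them has, and whether hydrogen in place of dimethylamino shifts it.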